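This account rests on a few compounds, and the source may have more. Where it says the series, first, only, none or still open, it means among the compounds named here.

Compound 1 `Clc1ccc(-c2cc(-c3cccnc3)nc(-c3ccsc3)c2)o1` is the pyridin-3-yl member of the series. In a functional assay on HCT-15 cells (Homo sapiens) for cytotoxicity, in the presence of a further agent that is not named here (on this read-out higher numbers stand for weaker inhibition and lower numbers for stronger inhibition), compound 1 gives only a limit, > 50000 nM, not a number. Compound 2 `Cc1ccc(-c2cc(-c3ccc(Cl)o3)cc(-c3ccsc3)n2)cc1` carries 4-methylphenyl instead, and in this assay compound 2 gives 7410 nM. The change from compound 1 to compound 2 brought an at least 6.7-fold lower number from compound 1 to compound 2 (0.82 log units; beyond the scatter); the size of that step is bounded by the limit of compound 1 (the limit of > 50000 nM in this assay, at which 1 of the 2 values shown sits). Within the data shown here, compound 2 therefore stands as the only numbered value in this assay, the other entry being a limit.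

Compound 3 `Clc1ccc(-c2cc(-c3ccsc3)nc(-c3ccccn3)c2)o1` replaces the 4-methylphenyl of compound 2 with pyridin-2-yl (pyridin-2-yl in place of 4-methylphenyl on an aromatic carbon). Among the measured compounds shown here, the only measured step that bears on this is the one from compound 1 to compound 2, where a pyridinyl gave way to 4-methylphenyl and the number fell by an at least 6.7-fold lower number from compound 1 to compound 2 (0.82 log units; beyond the scatter). Compound 3 moves back toward a pyridinyl, so the expectation is a step in the opposite direction, beyond the scatter, estimated as a 4.0-fold higher number from compound 2 to compound 3 (0.61 log units; beyond the scatter). For compound 3 the expected value in this assay is 30000 nM, within a range from 8000 nM to 60000 nM, with a real chance that only a limit is reported.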

Compound 3, half-maximal inhibitory concentration: > 50000 nM
Compound 3 gave a limit, no number (the forecaster's own chance of this, stated with the estimate: 40%); at least 1.6-fold (0.22 log units) between middle value and limit.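

In this assay, pyridin-2-yl in place of 4-methylphenyl on this aromatic carbon, next to the ring nitrogen, gives an at least 6.7-fold higher number from compound 2 to compound 3 (0.82 log units; beyond the scatter), so the loss seen earlier with pyridin-3-yl is not confined to that one pyridinyl. Among the three compounds shown, both pyridinyl members end at a limit and only the 4-methylphenyl member, compound 2, gives a number; none of the three goes against this pattern. The step between compound 1 and compound 3 cannot be read, so the two pyridinyl groups cannot be ordered, and the series now presses against the top of the range: the limit of > 50000 nM in this assay, at which 2 of the 3 values shown sit.

On these data alone, it remains open whether the difference follows the ring nitrogen of the pyridinyl groups or the methyl of compound 2; an unsubstituted phenyl, a 4-methoxyphenyl or a 4-aminophenyl at this position would help to separate the two. As far as these compounds go, the contribution of the 5-chlorofuran-2-yl and thiophen-3-yl groups also stays open; both are shared by all three compounds.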